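The source may report more compounds than this note shows. Statements on the series, on what has been measured and on what is new or still open speak of the compounds shown alone.

Measured compounds:
compound 1, `CCC/N=C1\S/C(=C\c2ccc(O)cc2)C(=O)N1c1ccccc1C`, 3.5
compound 2, `CCC/N=C1\S/C(=C\c2ccc(O)c(Cl)c2)C(=O)N1C1CCOCC1`, 3.7

Both were measured in a physicochemical assay for lipophilicity, read by HPLC, at pH 7.4; on this read-out lower numbers stand for lower lipophilicity and higher numbers for higher lipophilicity. Of the two numbers, compound 2 gives the higher one, 3.7, while compound 1 gives 3.5; the gap between them lies within the usual scatter, so the two cannot be told apart.

Compound 3, `CCC/N=C1\S/C(=C\c2ccc(O)c(Cl)c2)C(=O)N1c1ccccc1O`, has not yet been measured in this assay. It differs from compound 2 in a single place: 2-hydroxyphenyl in place of oxan-4-yl on an amide-type nitrogen in a ring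

Among the measured compounds shown here, no measured pair in this set shows a change of this kind, so the expected size of the step cannot be read off from a comparison of measured compounds. For the measured compounds named here, the only guide is the pair of values themselves: compound 1, which carries an aromatic group on that ring nitrogen, gives 3.5, and compound 2, which carries the oxan-4-yl group there, gives 3.7. On this basis the step from compound 2 to compound 3 is expected to be small, no change at the digits printed from compound 2 to compound 3 (within the scatter), and probably not beyond the scatter.

Compound 3 is therefore estimated at 3.7 in this assay, with a range from 3.2 to 4.2.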

Compound 3, distribution coefficient: 2.7
Compound 3: middle estimate off by 1.00 log units, on the high side; measured number below the stated range.
By their numbers in this assay, from the lowest: compound 3; then compounds 1 and 2 (each within the scatter of the next).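

Compounds 1 and 2 differ in more than one place, so their numbers could not show what the amide-type nitrogen in a ring does on its own, but this single exchange can: putting 2-hydroxyphenyl in place of oxan-4-yl there gives a clear change in this assay (a number 1.00 log units lower from compound 2 to compound 3 (beyond the scatter)), so the reading at this position depends on the group it carries. The exchange alters several things at once, since a non-aromatic ring with a hetero atom leaves, an aromatic ring of carbon only enters, and the entering group brings a hydrogen-bond donor that the leaving group lacks. Nothing measured here explains the size of this step or ties it to any one of those features.

From the compounds shown here alone, what stays open is whether the step belongs to the aromatic ring itself or to the hydroxyl group it carries. Phenyl without a substituent and 2-methoxyphenyl on the same nitrogen, with the rest of compound 2 kept, would be the single-place comparisons that could pull those two apart.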